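Series notes: cyclopropyl added to the benzyl ring of compound 1

The source may report more compounds than this note shows. Statements on the series, on what has been measured and on what is new or still open speak of the compounds shown alone.

Compound 1 `COc1cccc(NC(=O)c2nnn(Cc3ccccc3)c2N)c1` is the reference point of this small set. In an ADME assay on microsomes from liver (Mus musculus, strain CD1) for metabolic stability, read by HPLC, using NADPH, with a stated time of 30 min (on this read-out higher numbers stand for fast clearance and lower numbers for slow clearance), compound 1 gives 3.7 mL.min-1.g-1, the lower of the two numbers in hand. Compound 2 `COc1cccc(NC(=O)c2nnn(CC3CCN(C(=O)OC(C)(C)C)CC3)c2N)c1` differs from compound 1 in several places. In this assay compound 2 gives 10 mL.min-1.g-1; the gap between these two numbers lies beyond the usual scatter, so compound 1 is the more slowly cleared of the pair.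

Compound 3 `COc1cccc(NC(=O)c2nnn(Cc3ccc(C4CC4)cc3)c2N)c1` has not yet been run. Relative to compound 1 the change is cyclopropyl in place of hydrogen on an aromatic carbon. Among the measured compounds shown here, no pair of measured compounds isolates this change, so there is no direct precedent within the set. For this assay the step from compound 1 to compound 3 is expected to be upward and of modest size, near the edge of the scatter, as a 1.9-fold higher number from compound 1 to compound 3 (0.28 log units; within the scatter). Compound 3 is accordingly estimated at 7 mL.min-1.g-1, within a range from 3 mL.min-1.g-1 to 16 mL.min-1.g-1.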

Compound 3, intrinsic clearance in microsomes: 4.9 mL.min-1.g-1
Estimate against measurement, compound 3: 1.4-fold (0.15 log units) above; low and high end bracket the measured number.
By their numbers in this assay, from the lowest: compounds 1 and 3 (each within the scatter of the next); then compound 2.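

In this assay, among the compounds shown here, the phenyl to 4-cyclopropylphenyl change gives a 1.3-fold higher number from compound 1 to compound 3 (0.12 log units; within the scatter), the first step in the set that isolates a single change. At this position, para to a large group, cyclopropyl in place of hydrogen on an aromatic carbon therefore leaves the clearance read-out within the scatter of compound 1, so this one change is compatible with the low end of the numbers in hand. Nothing in the data on these compounds accounts for this result.

Going by these compounds, whether an amine, a carboxylic acid or a longer chain on the same aromatic carbon would also stay within the scatter of compound 1 remains open. Also open, on these data alone, is whether cyclopropyl on another carbon of the same ring would read the same way.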